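The source may hold more compounds than are shown below. What is called first, only, known or untested is meant among the compounds shown, and "the series" means these compounds.

Of the compounds shown here, three have been measured in a functional assay on PC-3 cells (Homo sapiens) for inhibition, read by sulforhodamine B assay; on this read-out higher numbers stand for weaker inhibition of growth and lower numbers for stronger inhibition of growth. Compound 1 `Oc1cccc2[nH]c(-c3ccc(-c4ccc(-c5ccc(OC(F)(F)F)cc5)cc4)cc3)nc12` gives 7410 nM; compound 2 `Oc1ccc(-c2ccc(-c3ccc(-c4nc5c(O)cccc5[nH]4)cc3)cc2)cc1` gives 190 nM; compound 3 `Cc1ccc2[nH]c(-c3ccc(-c4ccc(-c5ccc(OC(F)(F)F)cc5)cc4)cc3)nc2c1` gives 2010 nM. The change from compound 1 to compound 2 is hydrogen in place of trifluoromethyl on an oxygen on an aromatic ring, and it made a 39-fold lower number from compound 1 to compound 2 (1.59 log units; beyond the scatter). Compound 3 differs from compound 1 in its core: 5-methyl-1H-benzimidazol-2-yl in place of 4-hydroxy-1H-benzimidazol-2-yl on an aromatic carbon, with a 3.7-fold lower number from compound 1 to compound 3 (0.57 log units; beyond the scatter). Compound 4 `Cc1ccc2[nH]c(-c3ccc(-c4ccc(-c5ccc(O)cc5)cc4)cc3)nc2c1` is not yet measured; it differs from compound 3 by hydrogen in place of trifluoromethyl on an oxygen on an aromatic ring, the same change as from compound 1 to compound 2, the second time it occurs here, now made on the core of compound 3. Because the same change earlier made a 39-fold lower number from compound 1 to compound 2 (1.59 log units; beyond the scatter), compound 4 is expected to follow with a step of similar size, a 34-fold lower number from compound 3 to compound 4 (1.53 log units; beyond the scatter), though a single prior instance is thin support. Compound 4 is therefore estimated at 60 nM, with a range from 20 nM to 200 nM.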

Compound 4, concentration for 50% growth inhibition: 30000 nM
Beside the measured number, compound 4's estimate is 500-fold (2.70 log units) below it; the measured number lies above the stated range.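

The change from trifluoromethoxy to hydroxy does not carry from one core to the other in this assay, where it gives a 15-fold higher number from compound 3 to compound 4 (1.17 log units; beyond the scatter) and the two steps run in opposite directions: the same change on two cores in this assay, a 39-fold lower number (1.59 log units; beyond the scatter) from compound 1 to compound 2 and a 15-fold higher number (1.17 log units; beyond the scatter) from compound 3 to compound 4, 580-fold (2.76 log units) apart, beyond the scatter of two such steps. For these two pairs, both the size and the direction of the step depend on the core. Two pairs do not show which part of the core decides this, how the change behaves on any further core, or why the steps differ.

Still open, from the compounds shown here alone, is whether the hydroxy group on the core of compound 1 or the methyl group on the core of compound 3 sets the direction of the step. Also open, going by these compounds, is how an amine or a carboxylic acid in place of the trifluoromethoxy group would read on either core.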